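Two benzyloxyphenyl analogues and a third awaiting its number

The compounds below may be only part of what the source reports. "The series", "measured", "known", "first", "only" and "open" are said of these compounds alone.

Compound 1 `N#CCCn1nc(-c2ccc(OCc3cccc(Cl)c3)cc2)oc1=O` and compound 2 `COc1cccc(COc2ccc(-c3nn(CCC#N)c(=S)o3)cc2)c1` share a core and differ in two places at once, so no single change can be read off between them. In an assay for inhibition of Amine oxidase [flavin-containing] B (Rattus norvegicus) (a higher number here means a weaker inhibitor, a lower number a stronger inhibitor), compound 1 gives 12 nM, and compound 2 gives 100 nM. For the measured compounds named here, of the two numbers measured, compound 2 stands at the higher one, and its only neighbour is compound 1, whose lower number lies beyond the usual scatter of this assay.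

Compound 3 `N#CCCn1nc(-c2ccc(OCc3ccc(Cl)cc3)cc2)oc1=S` has not yet been measured. It is reached from compound 2 by one change: 4-chlorophenyl in place of 3-methoxyphenyl on a saturated chain carbon bound to an oxygen on an aromatic ring. Going by the values given here, no measured pair shows this exact change on its own, so the only guide is that the chlorinated compound 1 carries the lower number of the two.

For this assay, compound 3 is expected to show a moderate step toward a lower number, a 2.5-fold lower number from compound 2 to compound 3 (0.40 log units; beyond the scatter), rather than no change. Compound 3 is therefore estimated at 40 nM, within a range from 10 nM to 200 nM, and the measurement will tell.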

Compound 3, half-maximal inhibitory concentration: 690 nM
For compound 3 the middle estimate is 17-fold (1.24 log units) below the measured one, outside the stated range (above it).
By their numbers in this assay, from the lowest: compound 1; then compound 2; then compound 3.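

In this assay, for the compounds shown here, putting 4-chlorophenyl in place of 3-methoxyphenyl on a saturated chain carbon bound to an oxygen on an aromatic ring gives a 6.9-fold higher number from compound 2 to compound 3 (0.84 log units; beyond the scatter) and so provides the first reading of a single change, showing that this position responds and that this exchange leads toward a weaker inhibitor. It also shows that a chlorine on the phenyl ring does not by itself bring a low number, so the value of compound 1 sets no general rule for chlorinated compounds on this core. No measurement shown here accounts for the rise in the number.

The exchange alters both the substituent and its printed ring position, so the compounds shown leave open how much of the step belongs to the loss of methoxy, the arrival of chlorine or the move from 3 to 4. An unsubstituted phenyl or a 4-methoxyphenyl at this place, on the core of compound 2, could begin to separate these contributions.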